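Mirror-image stereoisomers of a tetrahydrofuran-bearing EZH2 inhibitor

A few compounds are considered here, and "the series" means these few. Any claim that something is new, unique, unknown or untested is made for them only; others in the source may bear on it.

Compound 1 `Cc1cc(C)c(CN2CCc3c(Cl)cc(-c4c(C)noc4C)c(Cl)c3C2=O)c(=O)[nH]1`: 17 nM
Compound 2 `Cc1cc(C)c(CN2CCc3c(Cl)cc([C@@H](CO)[C@H]4CCCO4)c(Cl)c3C2=O)c(=O)[nH]1`: 1020 nM

For the measured compounds named here, in an assay on cells for inhibition of histone-lysine N-methyltransferase EZH2 (Homo sapiens), read by ELISA, with a stated time of 72 h (a higher number here means a weaker inhibitor, a lower number a stronger inhibitor), compound 1 gives 17 nM and compound 2 gives 1020 nM, so compound 2 stands with the higher of the two numbers; the step of a 60-fold higher number from compound 1 to compound 2 (1.78 log units; beyond the scatter) is the only measured step, and it exchanges a whole group rather than a configuration. Compound 3 `Cc1cc(C)c(CN2CCc3c(Cl)cc([C@H](CO)[C@@H]4CCCO4)c(Cl)c3C2=O)c(=O)[nH]1` differs from compound 2 as follows: the two compounds have the same atoms and bonds and differ only in configuration as drawn: 2 of 2 stereo elements differ (all stereocentres are inverted: mirror images); a stereocentre at a saturated chain carbon is drawn S in compound 2 and R in compound 3; a stereocentre at a saturated ring carbon is drawn R in compound 2 and S in compound 3. Going by the values given here, no measured step bears on an inversion of configuration, so the direction of a 3.4-fold lower number from compound 2 to compound 3 (0.53 log units; beyond the scatter) is an expectation without direct support. Compound 3 is estimated at 300 nM, within 30 nM to 3000 nM.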

Compound 3, half-maximal inhibitory concentration in the histone-lysine N-methyltransferase EZH2 assay: 41 nM
For compound 3 the middle estimate is 7.3-fold (0.86 log units) above the measured one, within the range that was stated.
By their numbers in the histone-lysine N-methyltransferase EZH2 assay, from the lowest: compound 1; then compound 3; then compound 2.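

In the histone-lysine N-methyltransferase EZH2 assay this position proves highly sensitive to configuration, not only to which group it carries, with a 25-fold lower number from compound 2 to compound 3 (1.40 log units; beyond the scatter), and that gap can be assigned to configuration alone because of one fact: the fact that compounds 2 and 3 differ only in the configuration as drawn. In the histone-lysine N-methyltransferase EZH2 assay the group exchange costs far less in the right configuration, with a 2.4-fold higher number from compound 1 to compound 3 (0.38 log units; beyond the scatter). In a physicochemical assay for lipophilicity, at pH 7.4 (a lower number here means a more polar compound, a higher number a more lipophilic compound), compound 2 gives 2.5 and compound 3 gives 2.4, values within the usual scatter of each other.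

Both stereocentres invert together, leaving open which one carries the difference. Going by these compounds, the effect of an amine in place of the hydroxyl also remains open.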